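The compounds below may be only part of what the source reports. "The series", "measured", "known", "first", "only" and "open" are said of these compounds alone.

Compound 1 `C[C@]1(C(=O)O)CC[C@H](C(=O)N2CC[C@](c3ccc(C(F)(C(F)(F)F)C(F)(F)F)cc3)(S(=O)(=O)c3ccc(F)cc3)C2)CC1` is measured in an ADME assay on microsomes from liver (Mus musculus) for metabolic stability, with a stated time of 10 min (on this read-out higher numbers stand for a more stable compound and lower numbers for a less stable compound), where compound 1 gives 93%. Compound 3 `O=C(O)C12CCC(C(=O)N3CC[C@](c4ccc(C(F)(C(F)(F)F)C(F)(F)F)cc4)(S(=O)(=O)c4ccc(F)cc4)C3)(CC1)OC2` gives 94%, and compound 2 `O=C(O)C12CCC(C(=O)N3CC[C@](c4ccc(C(F)(C(F)(F)F)C(F)(F)F)cc4)(S(=O)(=O)c4ccc(F)cc4)C3)(CC1)CC2` gives 73%; compound 1 thus stands second highest of the three, close to compound 3 and well above compound 2, as a number 20 percentage points lower from compound 1 to compound 2 (beyond the scatter) shows. Compound 4 `O=C(N1CC[C@](c2ccc(C(F)(C(F)(F)F)C(F)(F)F)cc2)(S(=O)(=O)c2ccc(F)cc2)C1)C1(F)CCS(=O)(=O)CC1` differs from compound 1 in that (4-fluoro-1,1-dioxothian-4-yl in place of 4-carboxy-4-methylcyclohexyl on a carbonyl carbon). The measured steps all change the group on the same carbonyl carbon: a number 1 percentage points higher from compound 1 to compound 3 (within the scatter) and a number 21 percentage points higher from compound 2 to compound 3 (beyond the scatter) are the other two. Among the compounds with values here, none of them removes the carboxy group or brings in a sulfur-containing ring, so no step bears directly on this change. A modest drop is therefore expected, a number 18 percentage points lower from compound 1 to compound 4 (beyond the scatter), with compound 4 estimated at 75%, between 45% and 95%.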

Compound 4, percent of the compound remaining: 90%
Beside the measured number, compound 4's estimate is 15 percentage points below it; the range from low to high includes it.
By their numbers in this assay, from the lowest: compound 2; then compounds 4, 1 and 3 (each within the scatter of the next).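

In this assay, the carboxy group turns out not to be required at this carbonyl carbon: 4-fluoro-1,1-dioxothian-4-yl, which has no hydrogen-bond donor, leaves the reading essentially unchanged (a number 3 percentage points lower from compound 1 to compound 4 (within the scatter); a number 4 percentage points lower from compound 3 to compound 4 (within the scatter)). Compound 2 remains the lowest of the set (a number 17 percentage points higher from compound 2 to compound 4 (beyond the scatter)). No supporting measurement explains this result. The compounds shown do not separate the contribution of the fluorine from that of the ring sulfur with its two oxygens. On these data alone, whether a hydroxy group in place of that fluorine would give a similar reading also remains open.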